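Amide nitrogen substituent variation on the shared core

This account rests on a few compounds, and the source may have more. Where it says the series, first, only, none or still open, it means among the compounds named here.

Working notes on the series. The shared core carries an unsaturated amide side chain; compound 1 `COc1ccc2c(=O)c(/C=C/C(=O)Nc3ccccc3)coc2c1`, compound 2 `O=C(/C=C/c1coc2cc(O)ccc2c1=O)NCc1ccc(F)cc1` and compound 3 `Cc1ccccc1NC(=O)/C=C/c1coc2cc(O)ccc2c1=O` differ in the group on the amide nitrogen. In a functional assay (QGY7701 cells, Homo sapiens) for inhibition, read by MTT assay, with a stated time of 48 h (on this read-out higher numbers stand for weaker inhibition and lower numbers for stronger inhibition), compound 1 gives 14000 nM. For compound 2 the result in this assay is a limit of the assay, > 100000 nM, and not a number. Among the compounds with values here, compound 3 gives 9320 nM in this assay, the lowest of the two numbers so far; compound 1 sits nearest, within the usual scatter. Within the data shown here, the one measured step, an at least 10-fold lower number from compound 2 to compound 3 (1.03 log units; beyond the scatter), exchanges the whole group on the amide nitrogen and is large. Compound 4 `O=C(/C=C/c1coc2cc(O)ccc2c1=O)Nc1ccccc1` differs from compound 3 by hydrogen in place of methyl on an aromatic carbon, read one bond further out as 2-methylphenyl to phenyl, or (2-methylphenyl)amino to anilino. Among the measured compounds shown here, no measured step removes a methyl from an aromatic carbon, so the recorded step offers little direct guidance for a change this small. The change is expected to give a 1.3-fold higher number from compound 3 to compound 4 (0.11 log units; within the scatter), nothing beyond the scatter. For compound 4 the estimate in this assay is 12000 nM, with a range from 4000 nM to 40000 nM.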

Compound 4, half-maximal inhibitory concentration: 17900 nM
Estimate against measurement, compound 4: 1.5-fold (0.17 log units) below, and the stated range covers the measured number.
By their numbers in this assay, from the lowest: compounds 3, 1 and 4 (each within the scatter of the next). At a limit, above all of these: compound 2.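

Neither methyl removal moves the number beyond the scatter in this assay: hydrogen in place of methyl on the aromatic carbon, ortho to a large group, gives a 1.9-fold higher number from compound 3 to compound 4 (0.28 log units; within the scatter), and hydrogen in place of methyl on an oxygen on an aromatic ring gives a 1.3-fold higher number from compound 1 to compound 4 (0.11 log units; within the scatter). The large difference stays with the group on the amide nitrogen, since phenyl in place of 4-fluorobenzyl gives an at least 5.5-fold lower number from compound 2 to compound 4 (0.74 log units; beyond the scatter). The size of that step remains bounded, as compound 2 stands at a limit of the assay and not at a number: the limit of > 100000 nM in this assay, at which 1 of the 4 values shown sits.

A plain benzyl group on the amide nitrogen would separate the effect of the added carbon from that of the fluorine. From the compounds shown here alone, whether an amine or a carboxylic acid on the phenyl ring changes the number also remains open.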